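Sulfone series, cytotoxicity notes: from compound 2 to compound 3

The compounds below may be only part of what the source reports. "The series", "measured", "known", "first", "only" and "open" are said of these compounds alone.

Measured so far in an ADME assay on cells (Homo sapiens) for cytotoxicity, read by resazurin assay, with a stated time of 5 days; on this read-out higher numbers stand for lower toxicity in this test and lower numbers for higher toxicity in this test:
compound 1 `COc1ccc(-c2nc(C(C)(C)S(=O)(=O)c3cccc(Cl)c3)nc3ccsc23)cn1` gives > 50000 nM, a limit of the assay.
compound 2 `O=S(=O)(Cc1nc(-c2cccs2)c2sccc2n1)c1cccc(Cl)c1` gives > 50000 nM, likewise only a limit.

Compound 2 therefore sits at the assay limit, as recorded in the limit of > 50000 nM in this assay, at which 2 of the 2 values shown sit, and no number separates it from compound 1. Compound 3 `O=S(=O)(Cc1nc(-c2ccnc(Cl)c2)c2sccc2n1)c1cccc(Cl)c1` differs from compound 2 by 2-chloropyridin-4-yl in place of thiophen-2-yl on an aromatic carbon. Among the measured compounds shown here, no measured pair in this set shows what such a change does to cytotoxicity. Compound 3 is expected to stay at the limit as well, so the step of a number no higher from compound 2 to compound 3 (the limit leaves the size open) is expected to be none beyond the scatter. The estimate for compound 3 in this assay is 50000 nM, in the range 20000 nM to 120000 nM.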

Compound 3, half-maximal cytotoxic concentration: 63000 nM
Estimate against measurement, compound 3: 1.3-fold (0.10 log units) below, within the range that was stated.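

No step from compound 2 to compound 3 can be read in this assay, because the value of compound 2 is only a limit: the limit of > 50000 nM in this assay, at which 2 of the 3 values shown sit.

The compounds shown leave open what change, if any, 2-chloropyridin-4-yl in place of thiophen-2-yl brings to cytotoxicity.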